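Shortening the side chain of compound 2 toward compound 4

The source may hold more compounds than are shown below. What is called first, only, known or untested is meant among the compounds shown, and "the series" means these compounds.

Of the compounds shown here, three sharing a core have been measured in a functional assay on cells for antagonist activity at C-X-C chemokine receptor type 4 (Homo sapiens), read by fluorescence and calcium flux, with stated times of 25 min and 90 s; on this read-out lower numbers stand for stronger inhibition and higher numbers for weaker inhibition. Compound 2 `c1ccc2c(c1)CN[C@@H](CN(CCCCNCC1CCNCC1)[C@H]1CCCc3cccnc31)C2` gives 36.5 nM, the lowest of the three numbers; compound 3 `O=S1(=O)CCC(NCCCCN(C[C@H]2Cc3ccccc3CN2)[C@H]2CCCc3cccnc32)CC1` gives 45.5 nM, and compound 1 `c1ccc(CN(CCCCN(C[C@H]2Cc3ccccc3CN2)[C@H]2CCCc3cccnc32)Cc2ccccn2)nc1` gives 664 nM. The difference from compound 1 to compound 2 is large, whereas the step of a 1.2-fold higher number from compound 2 to compound 3 (0.10 log units; within the scatter) is within the scatter. Compound 4 `CC(C)(CCN)CN(C[C@H]1Cc2ccccc2CN1)[C@H]1CCCc2cccnc21` differs from compound 2 in the same region of the molecule: a group of 6 heavy atoms (5 carbon, 1 nitrogen; no ring) in place of a group of 11 heavy atoms (9 carbon, 2 nitrogen; one six-membered non-aromatic ring with 1 hetero atom), on a saturated chain carbon bound to an amine nitrogen. For the measured compounds named here, the only measured step that bears on this change, from compound 2 to compound 3, swapped one ring-bearing group for another and left the number essentially unchanged. The change to compound 4 removes the ring altogether and shortens the chain, a larger alteration than any measured one, so a moderate weakening rather than an unchanged number is expected. The estimate for compound 4 in this assay is 120 nM, between 40 nM and 400 nM, a step of a 3.3-fold higher number from compound 2 to compound 4 (0.52 log units; beyond the scatter) that is expected to exceed the scatter only modestly.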

Compound 4, half-maximal inhibitory concentration: > 33300 nM
Compound 4: no number, only a limit; the forecaster's own chance of this, stated with the estimate: 2%; at least 270-fold (2.44 log units) between middle value and limit.
By their numbers in this assay, from the lowest: compounds 2 and 3 (each within the scatter of the next); then compound 1. At a limit, above all of these: compound 4.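

With an at least 910-fold higher number from compound 2 to compound 4 (2.96 log units; beyond the scatter), the region on a saturated chain carbon bound to an amine nitrogen proves far more sensitive in this assay than the earlier swap suggested, where a 1.2-fold higher number from compound 2 to compound 3 (0.10 log units; within the scatter) had shown no change beyond the scatter. Among compound 2, compound 3 and compound 4, the two ring-bearing groups keep the numbers low and the group with no ring does not, although compound 1, which also carries rings, gives 664 nM. Compound 4 gives no number, only a limit, so the true size of this loss stays unknown: the limit of > 33300 nM in this assay, at which 1 of the 4 values shown sits.

The compounds shown leave open whether the lost ring or the shorter chain matters more, as the two change together in compound 4. A longer open chain ending in an amine would separate these two changes.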